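The source may hold more compounds than are shown below. What is called first, only, known or untested is meant among the compounds shown, and "the series" means these compounds.

Measured compounds:
compound 1 `O=C(O)COc1ccc(OCc2csc(-c3ccccc3)n2)cc1F` gives > 10000 nM
compound 2 `Cc1cc(OCc2csc(-c3ccccc3)n2)ccc1OCC(=O)O` gives > 10000 nM
compound 3 `O=C(O)COc1ccc(OCc2ncc(-c3ccccc3)o2)cc1F` gives > 10000 nM

In an assay on CHO cells for agonist activity at Free fatty acid receptor 1 (Homo sapiens), read by FLIPR (on this read-out lower numbers stand for an effect already at smaller amounts and higher numbers for an effect only at larger amounts of compound), each of these three values is only a limit of the assay, not a number; (the limit of > 10000 nM in this assay, at which 3 of the 3 values shown sit). Compound 1 and compound 2 differ by methyl in place of fluoro on an aromatic carbon, and the step that the two limits leave unreadable from compound 1 to compound 2 remains unreadable since both ends are limits. Compound 3 carries a different core, and the difference between the core of compound 1 and the core of compound 3 is not broken down here. Compound 4 `Cc1cc(OCc2ncc(-c3ccccc3)o2)ccc1OCC(=O)O` is made from compound 3 by the same change, (methyl in place of fluoro on an aromatic carbon). For compound 4 the expected step that the limit leaves unreadable from compound 3 to compound 4 rests on the unreadable step that the two limits leave unreadable from compound 1 to compound 2 and on (the limit of > 10000 nM in this assay, at which 3 of the 3 values shown sit), both pointing to another limit. Compound 4 is therefore expected to give 20000 nM, somewhere between 8000 nM and 60000 nM.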

Compound 4, half-maximal effective concentration: > 10000 nM
Compound 4 ended at the assay's limit (the forecaster's own chance of this, stated with the estimate: 85%); the middle value does not contradict the limit.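

No new step can be read from compound 3 to compound 4, because both values are limits and not numbers: the limit of > 10000 nM in this assay, at which 4 of the 4 values shown sit. The compounds shown leave open whether methyl in place of fluoro changes the read-out at all on either core.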